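Chloro substitution in a bis-thioester anilide series

This account rests on a few compounds, and the source may have more. Where it says the series, first, only, none or still open, it means among the compounds named here.

Compound 1 `O=C(CCCCC(S)CCS)Nc1ccccc1` and compound 2 `O=C(CCCCC(S)CCS)Nc1cccc(Cl)c1` carry a free dithiol chain; compound 3 `O=C(CCCCC(CCSC(=O)c1ccccc1)SC(=O)c1ccccc1)Nc1ccccc1` and compound 4 `O=C(CCCCC(CCSC(=O)c1ccccc1)SC(=O)c1ccccc1)Nc1ccccc1Cl` carry the same chain capped as two thioesters. How the two cores differ is not broken down here.

In a functional assay on Bel-7402 cells (Homo sapiens) for inhibition, read by MTT assay, with a stated time of 24 h, tested at 10 ug/mL (a higher number here means more inhibition of growth at the concentration tested, a lower number less inhibition of growth), compound 1 gives 3.72% and compound 2 gives 3.22%. The change between them, (chloro in place of hydrogen on an aromatic carbon), made a step of a number 0.5 percentage points lower from compound 1 to compound 2 (within the scatter). Compound 3 was reported as "not active" (no number reported) in this assay, with no number attached.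

The change from compound 3 to compound 4 is chloro in place of hydrogen on an aromatic carbon. Within the data shown here, it is the same kind of change as the one from compound 1 to compound 2, not the same: in the measured pair the chloro sits meta to a large group, whereas in compound 4 it sits ortho to a large group.

Compound 4 is expected to give a number of about the same size as the small step of a number 0.5 percentage points lower from compound 1 to compound 2 (within the scatter) would suggest, that is, essentially no inhibition, because compound 3 is reported as "not active" (no number reported) and the measured chloro step stayed within the scatter. For compound 4 the estimate in this assay is 3%, with a range from 0% to 12%; a report of no number at all is also quite possible.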

Compound 4, percent growth inhibition at one concentration: 6.63%
Beside the measured number, compound 4's estimate is 3.6 percentage points below it; measured number inside the range.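

Among these compounds, no step from compound 3 to compound 4 can be read in this assay: compound 3 carries no number, while compound 4 gives 6.63%. No measured evidence bears on this result. The compounds shown leave open how the free dithiol chain compares with the thioester-capped chain, and whether the position of the chloro matters on a shared core.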